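A few compounds are considered here, and "the series" means these few. Any claim that something is new, unique, unknown or untested is made for them only; others in the source may bear on it.

Among the compounds with values here, compound 3 `CCCc1ccc(-c2c(C)[nH]c(=O)n2C2CCCCC2)cc1` gives 13900 nM in a functional assay on brain (Rattus norvegicus, strain Wistar) for inhibition (a lower number here means a stronger inhibitor, a higher number a weaker inhibitor), the second highest of the three numbers so far, with compound 1 `CCCc1ccc(-c2c(C)[nH]c(=O)n2C)cc1` at 21500 nM and compound 2 `CCCCCCOc1ccc(-c2c(C)[nH]c(=O)n2C)cc1` at 7300 nM. Compound 4 `CCCCCCCOc1ccc(-c2c(C)[nH]c(=O)n2C2CCCCC2)cc1` differs from compound 3 by heptyloxy in place of propyl on an aromatic carbon. The step that bears on this is the one with hexyloxy in place of propyl on an aromatic carbon, a 2.9-fold lower number from compound 1 to compound 2 (0.47 log units; beyond the scatter), a modest move beyond the scatter; the cyclohexyl change, a 1.5-fold lower number from compound 1 to compound 3 (0.19 log units; within the scatter), stayed within the scatter. A heptyloxy chain is one carbon longer than hexyloxy, and a step of about the same size is expected, a 2.8-fold lower number from compound 3 to compound 4 (0.44 log units; beyond the scatter). Compound 4 is therefore estimated at 5000 nM, with a range of 2000 nM to 12000 nM.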

Compound 4, half-maximal inhibitory concentration: 11600 nM
The estimate for compound 4 lay 2.3-fold (0.37 log units) below the measured number, and the stated range covers the measured number.
By their numbers in this assay, from the lowest: compounds 2, 4, 3 and 1 (each within the scatter of the next, the first and the last beyond it).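

With cyclohexyl on the aromatic nitrogen, heptyloxy in place of propyl gives a 1.2-fold lower number from compound 3 to compound 4 (0.08 log units; within the scatter) and so stays within the scatter, whereas with methyl on that nitrogen, hexyloxy in place of propyl gave a 2.9-fold lower number from compound 1 to compound 2 (0.47 log units; beyond the scatter) and lay beyond it. The two steps differ in both the chain and the nitrogen group, so neither change alone can be held responsible for this contrast. Nothing measured here offers a reason for it.

Hexyloxy paired with cyclohexyl, or heptyloxy paired with methyl, would separate the two changes. Also open, on these data alone, is how an amine or a carboxylic acid in place of the chain on that aromatic carbon would read.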